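This account rests on a few compounds, and the source may have more. Where it says the series, first, only, none or still open, it means among the compounds named here.

Measured in an ADME assay on a cell-free system (serum, Homo sapiens) for metabolic stability, read by HPLC, tested at 2 mM; on this read-out higher numbers stand for a longer-lived compound and lower numbers for a shorter-lived compound:
- compound 1 `O=C(O[C@H]1C[C@H](n2cc(F)c(=O)[nH]c2=O)O[C@@H]1COP(=O)(O)Oc1ccc2ncccc2c1)c1ccccc1`: 16.5 h
- compound 2 `C[n+]1cccc(OP(=O)([O-])OC[C@H]2O[C@@H](n3cc(F)c(=O)[nH]c3=O)C[C@@H]2OC(=O)c2ccccc2)c1`: 37.3 h
- compound 3 `CCCCCCCCCC[n+]1cccc(OP(=O)([O-])OC[C@H]2O[C@@H](n3cc(F)c(=O)[nH]c3=O)C[C@@H]2OC(=O)c2ccccc2)c1`: 8.3 h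

Compound 3 lies within the scatter of compound 1, while compound 2 stands clearly higher. Compound 4 `O=C(O[C@H]1C[C@H](n2cc(F)c(=O)[nH]c2=O)O[C@@H]1COP(=O)([O-])Oc1ccc[n+](Cc2ccccc2)c1)c1ccccc1` keeps the shared core and changes one group: phenyl in place of nonyl on a saturated chain carbon bound to an aromatic nitrogen. Here phenyl takes the place of nonyl on a saturated chain carbon bound to an aromatic nitrogen. Among the measured compounds shown here, only one measured step bears on this place: a 4.5-fold lower number from compound 2 to compound 3 (0.65 log units; beyond the scatter), a modest one. Compound 4 carries neither hydrogen nor nonyl there, so it is expected to fall between compound 3 at 8.3 h and compound 2 at 37.3 h, nearer the lower value. The expected step is a 1.8-fold higher number from compound 3 to compound 4 (0.26 log units; within the scatter), a rise in this assay that would stay within the scatter. The estimate for compound 4 is 15 h, with an expected range of 7 h to 32 h.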

Compound 4, half-life: 14.4 h
The estimate for compound 4 lay 1.0-fold (0.02 log units) above the measured number, and the stated range covers the measured number.
By their numbers in this assay, from the lowest: compounds 3, 4 and 1 (each within the scatter of the next); then compound 2.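

In this assay, phenyl in place of hydrogen on this saturated chain carbon also brings a drop (a 2.6-fold lower number from compound 2 to compound 4 (0.41 log units; beyond the scatter)), so the fall seen with nonyl is not unique to that long chain. Between the two larger groups the change is small (a 1.7-fold higher number from compound 3 to compound 4 (0.24 log units; within the scatter)), so the ring and the open chain cannot be told apart here. No measurement at hand gives a reason for the drop.

Left open is how a mid-length chain such as butyl, or a benzyl carrying an amine or a carboxylic acid, would fare at this place. Whether any group larger than hydrogen can hold the number of compound 2 also stays unanswered.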